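Swapping cyclopentyl for propargyl on the ring amine

The source may hold more compounds than are shown below. What is called first, only, known or untested is meant among the compounds shown, and "the series" means these compounds.

The measured compounds in an assay on CHO cells for displacement of a labelled ligand from adenosine receptor A1 (Homo sapiens), read by scintillation counting, with a stated time of 1 h, tested at 1 uM (a lower number here means less inhibition, a higher number more inhibition at the concentration tested (going by the name of the read-out)), are:
compound 1 `CCCCC(=O)Nc1ncc(-c2cccc(Cl)c2)c(-c2ccccc2)n1` with 52%
compound 2 `O=C(Nc1ncc(-c2cccc(Cl)c2)c(-c2ccccc2)n1)C1CCC1` with 52%
compound 3 `Clc1cccc(-c2cnc(NC3CCCC3)nc2-c2ccccc2)c1`

For compound 3 this assay reports only a limit, > 80%. That puts compound 3 at the limit (the limit of > 80% in this assay, at which 1 of the 3 values shown sits), where one of the three values sits, so it is known only to lie at or beyond that mark rather than as a number.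

Compound 4 `C#CCNc1ncc(-c2cccc(Cl)c2)c(-c2ccccc2)n1` has not yet been measured. It differs from compound 3 in one place: propargyl in place of cyclopentyl on a nitrogen on an aromatic ring.

Going by the values given here, two measured steps touch the same nitrogen. Going from an amide to a plain cyclopentylamine gave a number at least 28 percentage points higher from compound 1 to compound 3 (beyond the scatter) and likewise a number at least 28 percentage points higher from compound 2 to compound 3 (beyond the scatter), while the amide pair itself showed no change at the digits printed from compound 1 to compound 2 (within the scatter). Compound 4 keeps the plain amine of compound 3 but carries a smaller, unbranched propargyl in its place. Since the gain in compound 3 may rest on the amine or on the cyclopentyl, some loss relative to compound 3 is expected, giving an estimated step of a number at least 20 percentage points lower from compound 3 to compound 4 (beyond the scatter).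

Compound 4 is therefore expected to give 60% in this assay, in a range from 30% to 85%.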

Compound 4, a percentage reported as inhibition, at one concentration (the size of the read-out at that concentration, not a potency): 76%
Compound 4: the middle estimate sits 16 percentage points below what was measured, within the range that was stated.
By their numbers in this assay, from the lowest: compounds 1 and 2 (each within the scatter of the next); then compound 4. At a limit, above all of these: compound 3.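

The propargylamino compound shows that the gain over the amides at this nitrogen does not depend on a ring, as the unbranched propargyl group also raises the number in this assay, giving a number 24 percentage points higher from compound 2 to compound 4 (beyond the scatter) and a number 24 percentage points higher from compound 1 to compound 4 (beyond the scatter). Against the cyclopentyl compound, the change reads a number at least 4 percentage points lower from compound 3 to compound 4 (that floor lies within the scatter), so this result neither establishes a real loss on replacing cyclopentyl with propargyl nor rules one out. Compound 3 is held at a limit of the assay rather than a number: the limit of > 80% in this assay, at which 1 of the 4 values shown sits.

The compounds shown leave open whether the triple bond of propargyl matters at all, and a plain propyl group or a cyclopropyl ring on the same nitrogen would help separate the triple bond from the size and shape of the group. Also open, from the compounds shown here alone, is how compound 3 and compound 4 truly compare, as each reading here is the size of an effect at one concentration and not a potency, and whether a longer chain or a larger ring on this nitrogen would keep the gain remains unknown.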